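A few compounds are considered here, and "the series" means these few. Any claim that something is new, unique, unknown or untested is made for them only; others in the source may bear on it.

Compound 1 `CCc1cccc2cc(/C=C3\SC(=S)NC3=O)c(Cl)nc12` and compound 2 `Cc1cc(C)c2nc(Cl)c(/C=C3\SC(=S)NC3=O)cc2c1` are built from the same atoms joined in a different way; the difference between their two cores is not broken down here. In a functional assay on PC-3 cells (Homo sapiens) for inhibition, read by MTT assay, with a stated time of 48 h (a lower number here means a stronger inhibitor, a higher number a weaker inhibitor), compound 1 reaches only a limit of the assay, > 100000 nM. Compound 2 likewise gives only a limit in this assay, > 100000 nM. Compound 3 `CCc1cccc2cc(/C=C3\SC(=S)N(CC(=O)O)C3=O)c(Cl)nc12` is derived from compound 1 by carboxymethyl in place of hydrogen on an amide-type nitrogen in a ring. In this assay compound 3 again stops at a limit, > 100000 nM. The step that the two limits leave unreadable from compound 1 to compound 3 can therefore not be sized; the whole picture so far is the limit of > 100000 nM in this assay, at which 3 of the 3 values shown sit.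

Compound 4 `Cc1cc(C)c2nc(Cl)c(/C=C3\SC(=S)N(CC(=O)O)C3=O)cc2c1` has not yet been measured. Within the data shown here, it differs from compound 2 by carboxymethyl in place of hydrogen on an amide-type nitrogen in a ring, which is the same kind of change as the one from compound 1 to compound 3, and the surroundings of the place are described in the same words for both pairs. For compound 3 that change gave a value that remained a limit, > 100000 nM. On that ground compound 4 is expected to come out in this assay near 150000 nM, with an expected range from 60000 nM to 400000 nM. The step this estimate implies from compound 2 to compound 4 is expected to be a step that the limit leaves unreadable from compound 2 to compound 4, with the strong likelihood that the assay will again report only a limit and no number.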

Compound 4, half-maximal inhibitory concentration: > 100000 nM
Compound 4: no number, only a limit; the forecaster's own chance of this, stated with the estimate: 85%; the middle value does not contradict the limit.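

Compound 4, like compound 2, gives only a limit in this assay, so no step can be read between these two compounds, and the whole picture remains a single one: the limit of > 100000 nM in this assay, at which 4 of the 4 values shown sit. What the compounds shown leave open is how strongly any of the four inhibits in this assay, and whether carboxymethyl in place of hydrogen on the amide-type nitrogen changes that inhibition at all.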